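Ester versus acid: working notes on compounds 1 to 4

This account rests on a few compounds, and the source may have more. Where it says the series, first, only, none or still open, it means among the compounds named here.

Measured so far:
compound 1 `COc1cc(/C=C/C(=O)O)ccc1OC(=O)c1nc(C)c(C)nc1C` gives 55.4% in a functional assay on EA.hy 926 cells (Homo sapiens) for cytotoxicity, read by MTT assay, with stated times of 24 h and 12 h, tested at 100 uM; a higher number here means a stronger effect of the compound at the concentration tested, a lower number a weaker effect;
compound 2 `CCOC(=O)/C=C/c1ccc(OC)cc1OC(=O)c1nc(C)c(C)nc1C` gives 39.9% in this assay;
compound 3 `COc1cc(/C=C/C(=O)O)cc(OC)c1OC(=O)c1nc(C)c(C)nc1C` gives 163% in this assay.

Compound 3 stands highest of the three numbers, with a number 107.6 percentage points higher from compound 1 to compound 3 (beyond the scatter). Compound 4 `CCOC(=O)/C=C/c1cc(OC)c(OC(=O)c2nc(C)c(C)nc2C)c(OC)c1` is not yet measured; it differs from compound 3 by ethyl in place of hydrogen on an oxygen next to a carbonyl group. Within the data shown here, no measured step covers this change in one place. Compound 2 also carries the ethoxycarbonyl group and sits lower than compound 1, but those two differ in a second place, so only their values can be compared. A moderate downward step is therefore expected. Compound 4 is expected to give 130%, with a range from 80% to 180%. The expected step is a number 33 percentage points lower from compound 3 to compound 4 (beyond the scatter).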

Compound 4, a percentage reported as activity, at one concentration (the size of the read-out at that concentration, not a potency): -47%
Compound 4: middle estimate off by 177 percentage points, on the high side; the whole stated range lies above it.
By their numbers in this assay, from the lowest: compound 4; then compound 2; then compound 1; then compound 3.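

The carboxy to ethoxycarbonyl change is now read in one place on the shared core, and in this assay it gives a number 210 percentage points lower from compound 3 to compound 4 (beyond the scatter). Among these compounds, compound 4 gives -47%, so this change alone takes the read-out below zero, which the earlier compounds did not show. Nothing at hand accounts for a step of this size.

As far as these compounds go, it remains open whether the step follows from the ethyl group itself or from the loss of the acid hydrogen. A methyl ester or a primary amide at this position would show how the read-out behaves between these two ends.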